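This account rests on a few compounds, and the source may have more. Where it says the series, first, only, none or still open, it means among the compounds named here.

In a functional assay on cells (Homo sapiens) for antiproliferative activity, read by sulforhodamine B assay, with a stated time of 48 h (on this read-out lower numbers stand for stronger inhibition and higher numbers for weaker inhibition), compound 3 (`CCCCCCCCCCCCNC(=O)[C@@H]1CSC(c2ccc(NC(C)=O)cc2)N1`) gives 2400 nM. This lies within the scatter of compound 2 (`CCCCCCCCCCCCNC(=O)[C@@H]1CSC(c2ccc(OC)c(OC)c2)N1`) at 2900 nM, while compound 1 (`CCCCCCCCNC(=O)[C@@H]1CSC(c2cc(OC)c(OC)c(OC)c2)N1`) shows a clearly higher number at 17100 nM. Compound 4 (`CCCCCCCCC/C=C\CCCCCCCNC(=O)[C@@H]1CSC(c2ccc(NC(C)=O)cc2)N1`) keeps the 4-acetamidophenyl group and alters only the chain: a group of 11 heavy atoms (11 carbon; no ring) in place of a group of 5 heavy atoms (5 carbon; no ring), on a saturated chain carbon, seven bonds along the chain from an amide-type nitrogen. Within the data shown here, the one measured step, a 1.2-fold lower number from compound 2 to compound 3 (0.08 log units; within the scatter), changes the aryl group and not the chain, so it offers little guidance. Among the measured compounds shown here, no measured step changes the chain alone. Octyl compound 1 at 17100 nM also differs from dodecyl compound 3 at 2400 nM in its aryl group, which makes it only a weak hint. The expected change, a 1.6-fold lower number from compound 3 to compound 4 (0.20 log units; within the scatter), is therefore small and towards a lower number. For compound 4 the estimated value is 1500 nM, with an expected range of 500 nM to 4500 nM.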

Compound 4, half-maximal inhibitory concentration: 1400 nM
Compound 4: middle estimate off by 1.1-fold (0.03 log units), on the high side; the measured number falls inside the stated range.
By their numbers in this assay, from the lowest: compounds 4, 3 and 2 (each within the scatter of the next, the first and the last beyond it); then compound 1.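

In this assay, among these compounds, the chain alone changes for the first time (a 1.7-fold lower number from compound 3 to compound 4 (0.23 log units; within the scatter)), and the step stays within the scatter. This position, seven bonds along the chain from an amide-type nitrogen, therefore takes the larger group with its double bond while the 4-acetamidophenyl group stays in place, without a clear change in the number. The data shown offer no evidence that bears on this result.

The step changes chain size and adds the double bond together, so a saturated chain of the same carbon count would be needed to separate the two. Going by these compounds, how an amine or a carboxylic acid on this chain would read remains open.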